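Working notes: exchange on the amine nitrogen

This account rests on a few compounds, and the source may have more. Where it says the series, first, only, none or still open, it means among the compounds named here.

- compound 1 `O=S(=O)(NCCNC(=S)Nc1cccc(Cl)c1)c1ccc(-c2ccccc2OCc2cccc(O)c2)s1`: 10700 nM
- compound 2 `COc1ccc(NC(=O)NCCNS(=O)(=O)c2ccc(-c3ccccc3OCc3ccccc3)s2)cc1`: > 50000 nM
- compound 3 `O=S(=O)(NCCNC(=S)Nc1cccc(Cl)c1)c1ccc(-c2ccccc2OCc2ccccc2)s1`: 8400 nM

For the measured compounds named here, in a functional assay on HeLa cells (Homo sapiens) for inhibition, read by CCK-8 assay, with a stated time of 48 h (a lower number here means a stronger inhibitor, a higher number a weaker inhibitor), compound 3 gives 8400 nM and compound 1 gives 10700 nM, two values within the scatter of each other and the only numbers in the set. For compound 2 only a limit is reported, > 50000 nM.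

Compound 4 `COc1cccc(NC(=O)NCCNS(=O)(=O)c2ccc(-c3ccccc3OCc3ccccc3)s2)c1` differs from compound 3 on an amine nitrogen: a group of 11 heavy atoms (8 carbon, 1 nitrogen, 2 oxygen; one six-membered aromatic ring of carbon only) in place of a group of 10 heavy atoms (7 carbon, 1 nitrogen, 1 sulfur, 1 chlorine; one six-membered aromatic ring of carbon only), on an amine nitrogen. The entering group is (3-methoxyphenyl)carbamoyl.

Going by the values given here, the closest precedent is an at least 5.9-fold lower number from compound 2 to compound 3 (0.77 log units; beyond the scatter), a step beyond the scatter in which the group given up has the same heavy-atom composition as the one entering here. The other measured step, a 1.3-fold lower number from compound 1 to compound 3 (0.11 log units; within the scatter), lies within the scatter and concerns a different place, so it adds little. A move to a higher number is therefore expected in this assay, and a report of only a limit is possible.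

The expected step is a 3.8-fold higher number from compound 3 to compound 4 (0.58 log units; beyond the scatter). For compound 4 the estimated value is 32000 nM, with an expected range from 12000 nM to 50000 nM.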

Compound 4, half-maximal inhibitory concentration: > 50000 nM
Compound 4: a limit, no number; the forecaster's own chance of this, stated with the estimate: 50%; at least 1.5-fold (0.19 log units) between middle value and limit.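

In this assay, placing (3-methoxyphenyl)carbamoyl on the amine nitrogen gives an at least 5.9-fold higher number from compound 3 to compound 4 (0.77 log units; beyond the scatter). The drop seen with the 4-methoxyphenyl group of compound 2 is therefore not particular to that group: with 3-methoxyphenyl in compound 4, the result at this nitrogen is again only a limit, not a number. The step between these two methoxyphenyl isomers cannot be read, and both compounds share the same ceiling: the limit of > 50000 nM in this assay, at which 2 of the 4 values shown sit.

On these data alone, how far compound 2 and compound 4 lie past that limit remains open, as does any order between them. Also open, as far as these compounds go, is whether the loss follows the carbonyl or the methoxyphenyl group; a chlorophenylcarbamoyl group or a methoxyphenyl group on a thiocarbonyl at the same nitrogen would separate the two.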